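The source may report more compounds than this note shows. Statements on the series, on what has been measured and on what is new or still open speak of the compounds shown alone.

Measured so far:
compound 1 `Cc1nc(S(C)(=O)=O)ccc1Oc1ncnc(OC2CCN(C(=O)OC(C)(C)C#N)CC2)c1F`, 92.9 nM
compound 2 `Cc1nc(S(C)(=O)=O)ccc1Oc1ncnc(OC2CCN(C(=O)SC(C)(C)C)CC2)c1F`, 4.83 nM
compound 3 `Cc1nc(S(C)(=O)=O)ccc1Oc1ncnc(OC2CCN(C(=O)C(F)(F)F)CC2)c1F`, 151 nM

In a functional assay on isolated protein for inhibition of Glucose-dependent insulinotropic receptor (Homo sapiens), read by HTRF and cAMP accumulation (on this read-out higher numbers stand for an effect only at larger amounts of compound and lower numbers for an effect already at smaller amounts), compound 3 stands at the highest of the three numbers; nearest to it lies compound 1, with a 1.6-fold higher number from compound 1 to compound 3 (0.21 log units; within the scatter), and furthest compound 2, with a 31-fold higher number from compound 2 to compound 3 (1.50 log units; beyond the scatter). Compound 4 `Cc1nc(S(C)(=O)=O)ccc1Oc1ncnc(OC2CCN(C(=O)c3noc(C(C)(C)F)n3)CC2)c1F` is not yet measured; it differs from compound 3 by a group of 9 heavy atoms (5 carbon, 2 nitrogen, 1 oxygen, 1 fluorine; one five-membered aromatic ring with 3 hetero atoms) in place of a group of 4 heavy atoms (1 carbon, 3 fluorine; no ring), on a carbonyl carbon. Going by the values given here, the steps that bear on this place are a 19-fold lower number from compound 1 to compound 2 (1.28 log units; beyond the scatter) and a 31-fold higher number from compound 2 to compound 3 (1.50 log units; beyond the scatter), both beyond the scatter, so exchanges on this carbonyl carbon have moved this assay strongly in either direction. Among the compounds with values here, no measured step involves a group with a ring, so the size and direction of the new step remain uncertain. Compound 4 is expected to give 40 nM in this assay, with a range of 8 nM to 250 nM. This estimate corresponds to a 3.8-fold lower number from compound 3 to compound 4 (0.58 log units; beyond the scatter).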

Compound 4, half-maximal effective concentration: 14 nM
Compound 4: the middle estimate sits 2.9-fold (0.46 log units) above what was measured; the range from low to high includes it.
By their numbers in this assay, from the lowest: compound 2; then compound 4; then compounds 1 and 3 (each within the scatter of the next).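

In this assay a group with a ring is accepted on this carbonyl carbon: an 11-fold lower number from compound 3 to compound 4 (1.03 log units; beyond the scatter) and a 6.6-fold lower number from compound 1 to compound 4 (0.82 log units; beyond the scatter). The (tert-butyl)sulfanyl group still gives the lowest number, with a 2.9-fold higher number from compound 2 to compound 4 (0.46 log units; beyond the scatter). Nothing at hand explains these steps.

From the compounds shown here alone, it remains open whether the five-membered aromatic ring with 3 hetero atoms or the fluorine-bearing carbon on it drives the gain. Going by these compounds, how a phenyl ring or an amine on this carbonyl carbon would read also remains open.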